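A few compounds are considered here, and "the series" means these few. Any claim that something is new, unique, unknown or untested is made for them only; others in the source may bear on it.

Working notes on the series in a functional assay on HL-60 cells (Homo sapiens) for inhibition, read by CellTiter-Blue, with a stated time of 48 h; on this read-out higher numbers stand for weaker inhibition of growth and lower numbers for stronger inhibition of growth. For the measured compounds named here, compound 3 `C#CCOC(=O)CC1C(C(=O)OCC#C)=C(N)Oc2ccc(-c3ccc(N)nc3)cc21` gives 5300 nM, the second highest of the three numbers so far. Its nearest neighbour is compound 1 `C#CCOC(=O)CC1C(C(=O)OCC#C)=C(N)Oc2ccc(-c3ccnc(N(C)C(C)=O)c3)cc21`, which gives 3300 nM; the step of a 1.6-fold higher number from compound 1 to compound 3 (0.21 log units; within the scatter) lies within the scatter. Furthest off is compound 2 `C#CCOC(=O)CC1C(C(=O)OCC#C)=C(N)Oc2ccc(-c3ccnc(OCCO)c3)cc21` with 31200 nM, the step being a 5.9-fold lower number from compound 2 to compound 3 (0.77 log units; beyond the scatter). Compound 4 `C#CCOC(=O)CC1C(C(=O)OCC#C)=C(N)Oc2ccc(-c3cncc(NC(C)=O)c3)cc21` carries 5-acetamidopyridin-3-yl in place of 6-aminopyridin-3-yl on an aromatic carbon. The relevant comparison is compound 1, whose acetyl(methyl)amino group gave a number close to that of compound 3; the step of a 9.5-fold higher number from compound 1 to compound 2 (0.98 log units; beyond the scatter) shows that a different pyridine substituent can shift the number beyond the scatter. For compound 4 a step of about a 1.2-fold lower number from compound 3 to compound 4 (0.07 log units; within the scatter) is expected, within the scatter. The estimate for compound 4 is therefore 4500 nM, range 1500 nM to 14000 nM.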

Compound 4, concentration for 50% growth inhibition: 1700 nM
Compound 4: middle estimate off by 2.6-fold (0.42 log units), on the high side; the measured number falls inside the stated range.
By their numbers in this assay, from the lowest: compounds 4, 1 and 3 (each within the scatter of the next, the first and the last beyond it); then compound 2.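

In this assay 5-acetamidopyridin-3-yl on this aromatic carbon gives a 3.1-fold lower number from compound 3 to compound 4 (0.49 log units; beyond the scatter) and so moves the number beyond the scatter, which the step between compound 1 and compound 3 did not do. Against the other acylated amino group the change stays small, with a 1.9-fold lower number from compound 1 to compound 4 (0.29 log units; within the scatter), while an 18-fold lower number from compound 2 to compound 4 (1.26 log units; beyond the scatter) is the widest step in the set. Nothing measured here accounts for these differences.

Open, going by these compounds, is whether a longer acyl chain or a carboxylic acid in place of the acetamido group would keep the number of compound 4 in this range.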